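A few compounds are considered here, and "the series" means these few. Any claim that something is new, unique, unknown or untested is made for them only; others in the source may bear on it.

Of the compounds shown here, three share one core and have been tested in a functional assay on MCF7 cells (Homo sapiens) for inhibition, read by fluorescence, with a stated time of 72 h; on this read-out lower numbers stand for stronger inhibition of growth and higher numbers for weaker inhibition of growth. Compound 1 `CCCCCc1cc2nn(-c3ccccc3)cc2cn1` carries a pentyl group, and in this assay compound 1 gives 11800 nM. Compound 2 `Cc1nc(-c2ccccc2)cc2nn(-c3ccccc3)cc12` gives 11000 nM and compound 3 `CCCCCc1cc2nn(-c3ccccc3)cc2c(C)n1` gives 17000 nM, so all three numbers lie within the usual scatter of one another and compound 1 cannot be set apart from either neighbour.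

Compound 4 `c1ccc(-n2cc3cnc(C4CC4)cc3n2)cc1` differs from compound 1 in one place: cyclopropyl in place of pentyl on an aromatic carbon. Two measured steps speak to how tolerant this position is. The step of a 1.5-fold higher number from compound 2 to compound 3 (0.19 log units; within the scatter) swaps one group for another at the very same carbon and stays within the scatter, and the step of a 1.4-fold higher number from compound 1 to compound 3 (0.16 log units; within the scatter), a change elsewhere on the core, is also within the scatter. With every change seen so far leaving this assay essentially unmoved, the expected step of a 1.0-fold higher number from compound 1 to compound 4 (0.01 log units; within the scatter) is none beyond the scatter. Compound 4 is therefore estimated at 12000 nM, with a likely range from 5000 nM to 30000 nM.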

Compound 4, concentration for 50% growth inhibition: 69300 nM
Compound 4: the middle estimate sits 5.8-fold (0.76 log units) below what was measured; measured number outside the range, above it.
By their numbers in this assay, from the lowest: compounds 2, 1 and 3 (each within the scatter of the next); then compound 4.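

Within the data shown here, replacing pentyl with cyclopropyl in this assay is the first single change in this set to move beyond the scatter, with a 5.9-fold higher number from compound 1 to compound 4 (0.77 log units; beyond the scatter) showing weaker inhibition of growth. The earlier step of a 1.5-fold higher number from compound 2 to compound 3 (0.19 log units; within the scatter) had suggested that this carbon, next to the ring nitrogen, tolerates change, but that held only for pentyl and phenyl, on a core that also carries a methyl. The new result shows that the group at this position can matter, although the step is only modest in size and rests on a single pair of compounds.

As far as these compounds go, whether a straight propyl chain, a longer chain such as octyl or an amine at this carbon would track with pentyl or with cyclopropyl remains open. Nothing measured here explains why cyclopropyl gives the higher number.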